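A few compounds are considered here, and "the series" means these few. Any claim that something is new, unique, unknown or untested is made for them only; others in the source may bear on it.

Values so far in an ADME assay on L02 cells (Homo sapiens) for inhibition, read by CCK-8 assay, with a stated time of 48 h; on this read-out higher numbers stand for weaker inhibition of growth and lower numbers for stronger inhibition of growth

compound 1 `Cc1ccccc1Nc1nc(Nc2ccc(N3CCN(C)CC3)cn2)ncc1Cl` gives 5980 nM
compound 2 `CN1CCN(c2ccc(Nc3ncc(Cl)c(NCc4ccc(F)cc4)n3)nc2)CC1` gives 39700 nM
compound 3 `COc1cccc(CNc2nc(Nc3ccc(N4CCN(C)CC4)cn3)ncc2Cl)c1` gives 16200 nM

Compound 3 stands second highest of the three numbers (16200 nM) and is separated from both neighbours by more than the scatter. The next change leads to compound 4 (`CC(C)c1ccc(Nc2nc(Nc3ccc(N4CCN(C)CC4)cn3)ncc2Cl)cc1`) and reads 4-isopropylphenyl in place of 3-methoxybenzyl on a nitrogen on an aromatic ring (in words, 4-isopropylphenyl in place of 3-methoxybenzyl on a nitrogen on an aromatic ring).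

Compound 4 thus carries a substituted phenyl on that nitrogen, like compound 1, whereas compound 2 and compound 3 carry benzyl groups. The most relevant measurement is a 2.7-fold higher number from compound 1 to compound 3 (0.43 log units; beyond the scatter) and it is read here in reverse. A second measurement points the same way: a 6.6-fold higher number from compound 1 to compound 2 (0.82 log units; beyond the scatter) Both benzyl groups therefore sit higher than the 2-methylphenyl group, and neither goes against this, although the comparison rests on a single phenyl example. For the measured compounds named here, changing the benzyl group alone also moved the number modestly: a 2.5-fold lower number from compound 2 to compound 3 (0.39 log units; beyond the scatter) No measurement yet covers a 4-isopropylphenyl group.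

A modest move to a lower number is expected, close in size to the reverse of the first step. The estimated step is a 2.7-fold lower number from compound 3 to compound 4 (0.43 log units; beyond the scatter) (an expectation only). Compound 4 is estimated at 6000 nM (expected range 2200 nM to 16000 nM).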

Compound 4, concentration for 50% growth inhibition: 13700 nM
Compound 4: the middle estimate sits 2.3-fold (0.36 log units) below what was measured, within the range that was stated.
By their numbers in this assay, from the lowest: compound 1; then compounds 4 and 3 (each within the scatter of the next); then compound 2.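

In this assay, putting 4-isopropylphenyl in place of 3-methoxybenzyl on a nitrogen on an aromatic ring gives a 1.2-fold lower number from compound 3 to compound 4 (0.07 log units; within the scatter), so at this position compound 3 and compound 4 cannot be told apart, even though one carries a benzyl group and the other a substituted phenyl. A simple split of phenyl against benzyl therefore does not hold across the series: compound 4 goes against it, as a 2.3-fold higher number from compound 1 to compound 4 (0.36 log units; beyond the scatter) separates the two substituted phenyl groups beyond the scatter, while a 2.9-fold lower number from compound 2 to compound 4 (0.46 log units; beyond the scatter) shows that the 4-fluorobenzyl group of compound 2 also stands apart from the 4-isopropylphenyl group. No measurement is available that explains these differences.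

No two compounds shown carry the same substituent on both a phenyl and a benzyl group, so the effect of the saturated chain carbon cannot be separated from that of the substituent on the ring. Also open, from the compounds shown here alone, is how the number would respond to an unsubstituted phenyl, a 4-aminophenyl or a 4-carboxyphenyl group on the same nitrogen.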